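Replacing a Chloropropyl Arm by a Chloroacetyl Group

This account rests on a few compounds, and the source may have more. Where it says the series, first, only, none or still open, it means among the compounds named here.

Three ureas have so far been tested in a functional assay on MCF7 cells (Homo sapiens) for antiproliferative activity, with a stated time of 48 h; on this read-out lower numbers stand for stronger inhibition and higher numbers for weaker inhibition. Compound 1 `O=C(NCCCCl)Nc1ccc(I)cc1` gives only a limit in this assay, > 100000 nM. Compound 3 `CCCCC(OC)c1cccc(NC(=O)NCCCCl)c1` gives 50000 nM. Compound 2 `CC(C)(C)c1ccc(CNC(=O)NCCCCl)cc1` gives 17000 nM in this assay, the lowest of the two numbers shown; its nearest neighbour is compound 3, which sits beyond the usual scatter. The remaining entry belongs to compound 1 and is a limit of the assay rather than a number (the limit of > 100000 nM in this assay, at which 1 of the 3 values shown sits).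

Compound 4 `CC(C)(C)c1ccc(CNC(=O)NC(=O)CCl)cc1` has not yet been measured in this assay. It differs from compound 2 in one place: (chloromethyl)carbonyl in place of 3-chloropropyl on an amide-type nitrogen. Cut one bond further out, the same difference reads (3-chloropropyl)amino to ((chloromethyl)carbonyl)amino. Among the measured compounds no pair shows this exchange, so no measured step gives its size. The account therefore rests on compound 2 alone and on the change itself.

The step from compound 2 to compound 4 is expected to lower the number by a modest amount, a 2.1-fold lower number from compound 2 to compound 4 (0.33 log units; beyond the scatter), though a result within the scatter would not surprise. Compound 4 is estimated to give about 8000 nM in this assay, expected to lie between 2000 nM and 40000 nM.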

Compound 4, half-maximal inhibitory concentration: 2800 nM
Estimate against measurement, compound 4: 2.9-fold (0.46 log units) above; measured number inside the range.
By their numbers in this assay, from the lowest: compound 4; then compound 2; then compound 3. At a limit, above all of these: compound 1.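

In this assay, the exchange of 3-chloropropyl for (chloromethyl)carbonyl on the amide-type nitrogen now has a measured size, a 6.1-fold lower number from compound 2 to compound 4 (0.78 log units; beyond the scatter), and this is the only step shown at this position. It shows that the position responds to a change that leaves the count of heavy atoms in the group the same and keeps the chlorine, while the entering group brings a carbonyl and a hydrogen-bond acceptor. Nothing measured here bears on why the number falls, so the step stands as an observation about this one pair, on the substituents of compound 2 and compound 4 alone.

The compounds shown leave open whether the carbonyl, the shorter chain or the two together account for the step, and an acetyl group without the chlorine or a 2-chloroethyl chain on the same nitrogen would separate these. They also leave open whether the chlorine is needed at all, and whether the same exchange gives a step of similar size on a core other than that of compound 2.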